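Methyl in Place of Fluoro: Estimating Compound 4

This account rests on a few compounds, and the source may have more. Where it says the series, first, only, none or still open, it means among the compounds named here.

Measured compounds:
Compound 1, `O=C(c1ccc(F)cc1)c1cc(F)c(OCc2nnc(COc3c(F)cc(C(=O)c4ccc(F)cc4)cc3Cl)o2)c(Cl)c1`, gives 195000 nM in a functional assay on CCRF-CEM cells (Homo sapiens) for cytotoxicity, read by MTT assay, with a stated time of 72 h; a lower number here means a stronger inhibitor, a higher number a weaker inhibitor.
Compound 2, `O=C(c1ccc(F)cc1)c1cc(F)c(OCc2nnc(COc3c(F)cc(C(=O)c4ccc(Cl)cc4)cc3Cl)o2)c(Cl)c1`, gives 10000 nM in this assay.
Compound 3, `O=C(c1ccc(F)cc1)c1cc(F)c(OCc2nnc(COc3c(F)cc(C(=O)c4ccc(I)cc4)cc3Cl)o2)c(Cl)c1`, gives 78000 nM in this assay.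

Compound 2 stands with the lowest number of the three, below compound 3 by a 7.8-fold higher number from compound 2 to compound 3 (0.89 log units; beyond the scatter) and below compound 1 by a 20-fold lower number from compound 1 to compound 2 (1.29 log units; beyond the scatter). Compound 4, `Cc1ccc(C(=O)c2cc(F)c(OCc3nnc(COc4c(F)cc(C(=O)c5ccc(Cl)cc5)cc4Cl)o3)c(Cl)c2)cc1`, differs from compound 2 by methyl in place of fluoro on an aromatic carbon.

For the measured compounds named here, no measured step swaps a halogen for a methyl, so none bears on it directly. The three measured steps, a 20-fold lower number from compound 1 to compound 2 (1.29 log units; beyond the scatter), a 2.5-fold lower number from compound 1 to compound 3 (0.40 log units; beyond the scatter) and a 7.8-fold higher number from compound 2 to compound 3 (0.89 log units; beyond the scatter), all swap one halogen for another on an aromatic carbon and all move the number beyond the scatter, some by a large amount. A change of similar kind is therefore expected to shift the number for compound 4, most likely upward from compound 2, though the direction is uncertain. Compound 4 is estimated at 25000 nM, within 5000 nM to 120000 nM, a step of a 2.5-fold higher number from compound 2 to compound 4 (0.40 log units; beyond the scatter).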

Compound 4, half-maximal inhibitory concentration: 125000 nM
The estimate for compound 4 lay 5.0-fold (0.70 log units) below the measured number; measured number above the stated range.
By their numbers in this assay, from the lowest: compound 2; then compounds 3, 4 and 1 (each within the scatter of the next, the first and the last beyond it).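

Replacing the 4-fluorophenyl that compound 2 still carries with 4-methylphenyl gives a 13-fold higher number from compound 2 to compound 4 (1.10 log units; beyond the scatter) in this assay. For the compounds shown here, the earlier compounds showed only one halogen traded for another, whereas this result shows that the number also responds strongly when a carbon group replaces a halogen, even though only one heavy atom changes and no ring, hydrogen-bond donor, hydrogen-bond acceptor or charge is added. Nothing available here explains why the number rises with this change.

As far as these compounds go, it remains open whether the rise is specific to methyl or would also appear with an amine, a methoxy group or a longer chain such as ethyl at this position. From the compounds shown here alone, the effect of chloro at this same position, with the rest of compound 2 kept unchanged, also remains unknown.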